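The source may hold more compounds than are shown below. What is called first, only, known or untested is meant among the compounds shown, and "the series" means these compounds.

Compound 1 `COc1cc(NC(=O)NC(=O)c2cccc(NC(=O)CBr)c2)cc(OC)c1OC` gives 330 nM in a functional assay on CCRF-CEM cells (Homo sapiens) for antiproliferative activity, read by MTT assay, with a stated time of 72 h; on this read-out higher numbers stand for weaker inhibition and lower numbers for stronger inhibition. Compound 2 `COc1cc(NC(=O)NC(=O)c2cccc(NC(=O)C(C)Br)c2)cc(OC)c1OC` carries methyl in place of hydrogen on a saturated chain carbon bound to a bromine atom and a carbonyl carbon; in this assay compound 2 gives 1330 nM, and the step is a 4.0-fold higher number from compound 1 to compound 2 (0.61 log units; beyond the scatter). Compound 3 `O=C(CBr)Nc1cccc(C(=O)NC(=O)Nc2ccccn2)c1` rests on a different core; how the two cores differ is not broken down here. In this assay compound 3 gives 700 nM, a number that stands above that of compound 1 and close to that of compound 2. Compound 4 `CC(Br)C(=O)Nc1cccc(C(=O)NC(=O)Nc2ccccn2)c1` is drawn from compound 3 by methyl in place of hydrogen on a saturated chain carbon bound to a bromine atom and a carbonyl carbon, the same change, at the same place, as that made from compound 1 to compound 2. Among the compounds with values here, for compound 4 the step of a 3.4-fold higher number from compound 3 to compound 4 (0.54 log units; beyond the scatter) in this assay is expected, because a 4.0-fold higher number from compound 1 to compound 2 (0.61 log units; beyond the scatter) is the one measured example of this change and gives the only guide to its size. Compound 4 is therefore estimated at 2400 nM in this assay, expected to fall between 1000 nM and 6000 nM, a range kept wide since a single precedent is all that supports it.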

Compound 4, half-maximal inhibitory concentration: 6230 nM
For compound 4 the middle estimate is 2.6-fold (0.41 log units) below the measured one; measured number above the stated range.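

In this assay, methyl in place of hydrogen on the saturated chain carbon bound to a bromine atom and a carbonyl carbon gives an 8.9-fold higher number from compound 3 to compound 4 (0.95 log units; beyond the scatter), so bromomethyl to 1-bromoethyl raises the number on this core as well, and the two steps agree in direction and, within the scatter, in size: the same change on two cores in this assay, a 4.0-fold higher number (0.61 log units; beyond the scatter) from compound 1 to compound 2 and an 8.9-fold higher number (0.95 log units; beyond the scatter) from compound 3 to compound 4, 2.2-fold (0.34 log units) apart, within the scatter of two such steps. The change therefore carries from the core of compound 1 to the core of compound 3, and the gap between its two steps gives no ground for saying that its size depends on the core. Within the data shown here, this rests on only two pairs, however, so it does not show that the change would behave the same way on a further core, nor does it explain why the number rises.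

The compounds shown leave open whether a longer chain, such as ethyl in place of the methyl, would raise the number further. They also leave open what chlorine in place of the bromine would do on either core.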